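The source may hold more compounds than are shown below. What is called first, only, known or untested is meant among the compounds shown, and "the series" means these compounds.

In an assay on membranes from HEK293 cells for displacement of a labelled ligand from adenosine receptor A2b (Homo sapiens), read by scintillation counting, with a stated time of 30 min (a higher number here means a weaker inhibitor, a lower number a stronger inhibitor), compound 3 `CC1=C(C(=O)OC2CCC2)C(c2ccco2)NC(=O)N1` gives 95.1 nM, the lowest of the three numbers: compound 1 `CCCOC(=O)C1=C(C)NC(=O)NC1c1ccoc1` gives 1190 nM and compound 2 `CC1=C(C(=O)OC(C)(C)C)C(c2ccoc2)NC(=O)N1` gives 4440 nM. Going by the values given here, the only step measured in one place, a 3.7-fold higher number from compound 1 to compound 2 (0.57 log units; beyond the scatter), concerns the ester and not the aromatic ring. Compound 4 `CC1=C(C(=O)OC2CCC2)C(c2ccoc2)NC(=O)N1` differs from compound 3 by furan-3-yl in place of furan-2-yl on a saturated ring carbon. Among the compounds with values here, no measured step isolates this change; compounds 1 and 2 carry furan-3-yl and both give higher numbers than compound 3, but each also carries a different ester, so their values show no more than that. A weakening in this assay is therefore expected, and compound 4 is estimated at 400 nM (range 150 nM to 1200 nM), a step of a 4.2-fold higher number from compound 3 to compound 4 (0.62 log units; beyond the scatter).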

Compound 4, inhibition constant: 307 nM
Estimate against measurement, compound 4: 1.3-fold (0.11 log units) above; low and high end bracket the measured number.
By their numbers in this assay, from the lowest: compound 3; then compound 4; then compound 1; then compound 2.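

With cyclobutyl held on the ester oxygen, the furan attachment alone shifts the number in this assay: furan-3-yl in place of furan-2-yl on this saturated ring carbon gives a 3.2-fold higher number from compound 3 to compound 4 (0.51 log units; beyond the scatter) as an isolated step. With furan-3-yl held, the esters can now be compared directly: cyclobutyl in place of tert-butyl gives a 14-fold lower number from compound 2 to compound 4 (1.16 log units; beyond the scatter) and is the larger step, while cyclobutyl in place of propyl gives a 3.9-fold lower number from compound 1 to compound 4 (0.59 log units; beyond the scatter) in the same direction.

Going by these compounds, how a thiophene or phenyl ring on this carbon, or a longer chain on the ester oxygen, would read remains open. No evidence is available that bears on the reason for these steps.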